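A few compounds are considered here, and "the series" means these few. Any claim that something is new, unique, unknown or untested is made for them only; others in the source may bear on it.

Measured compounds in the series:
- compound 1, `CC(=O)NC1CCN(c2ncnc3[nH]cc(-c4cccc(Cl)c4)c23)CC1`: 139 nM
- compound 2, `OC1CCN(c2ncnc3[nH]cc(-c4cccc(Cl)c4)c23)CC1`: 433 nM
- compound 3, `CNC1CCN(c2ncnc3[nH]cc(-c4cccc(Cl)c4)c23)CC1`: 417 nM

All three share one core and differ only in the group on the saturated ring carbon. In an assay on HEK293T cells for displacement of a labelled ligand from serine/threonine-protein kinase 3 (Homo sapiens), read by NanoBRET, with a stated time of 2 h (a higher number here means a weaker inhibitor, a lower number a stronger inhibitor), compound 1 gives 139 nM, and it stands apart from the other two: a 3.1-fold higher number from compound 1 to compound 2 (0.49 log units; beyond the scatter) and a 3.0-fold higher number from compound 1 to compound 3 (0.48 log units; beyond the scatter). Compound 3 sits second highest of the three numbers; the nearest step is a 1.0-fold lower number from compound 2 to compound 3 (0.02 log units; within the scatter), so the two cannot be told apart, while compound 1 is clearly stronger.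

Compound 4, `Clc1cccc(-c2c[nH]c3ncnc(N4CCCCC4)c23)c1`, is not yet measured. The change from compound 3 is hydrogen in place of methylamino on a saturated ring carbon. Within the data shown here, no measured step removes the substituent entirely, so the closest guide is the pair of steps away from compound 1, which each cost a modest amount, and the step from compound 2 to compound 3, which cost nothing. Taking away the methylamino group entirely is expected to cost something further in this assay, of modest size, in the weaker direction: the estimated step is a 1.9-fold higher number from compound 3 to compound 4 (0.28 log units; within the scatter). Compound 4 is therefore expected at about 800 nM, with a range of 300 nM to 2500 nM.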

Compound 4, half-maximal inhibitory concentration: 1100 nM
The estimate for compound 4 lay 1.4-fold (0.14 log units) below the measured number; low and high end bracket the measured number.
By their numbers in this assay, from the lowest: compound 1; then compounds 3 and 2 (each within the scatter of the next); then compound 4.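

Compound 4 carries only hydrogen at this carbon and has the highest number in the series in this assay, with a 2.6-fold higher number from compound 3 to compound 4 (0.42 log units; beyond the scatter) on losing methylamino, a 2.5-fold higher number from compound 2 to compound 4 (0.40 log units; beyond the scatter) on losing hydroxy and a 7.9-fold higher number from compound 1 to compound 4 (0.90 log units; beyond the scatter) on losing acetamido. The earlier compounds shown here only compared substituents with one another, whereas these steps set all three against hydrogen and show that each of the three groups on this saturated ring carbon gives a stronger inhibitor than the plain piperidin-1-yl compound, so hydroxy and methylamino are not neutral here even though they cannot be told apart from each other. No measured evidence accounts for the size of any of these steps, so the result stands as a description of the numbers only.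

Still open, going by these compounds, is whether a primary amine, a carboxylic acid or a longer acyl chain on this carbon would match or pass acetamido. The compounds shown also leave open whether a substituent at another carbon of the piperidine ring would give a similar step from hydrogen.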